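The compounds below may be only part of what the source reports. "The series", "measured", "known", "first", "only" and "open" are said of these compounds alone.

Measured compounds:
- compound 1 `COc1ccc2oc(C(c3ccc(Cl)cc3)n3cncn3)cc2c1`: 2.01 nM
- compound 2 `Oc1ccc2oc(C(c3ccc(Cl)cc3)n3cncn3)cc2c1`: 5.67 nM
- compound 3 `CC#CCOc1ccc2cc(C(c3ccc(F)cc3)n3cncn3)oc2c1`: 4.1 nM

In an assay on JEG-3 cells for inhibition of Aromatase (Homo sapiens), with a stated time of 1 h (on this read-out higher numbers stand for weaker inhibition and lower numbers for stronger inhibition), compound 2 gives the highest of the three numbers. Within the data shown here, its nearest neighbour is compound 3, whose value lies within the scatter of it, while compound 1 lies furthest away, and the only single-point step among the measured compounds is a 2.8-fold higher number from compound 1 to compound 2 (0.45 log units; beyond the scatter), in which the methyl on the oxygen was replaced by hydrogen.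

Compound 4 `CCC#CCOc1ccc2oc(C(c3ccc(Cl)cc3)n3cncn3)cc2c1` has not yet been measured. It differs from compound 2 by pent-2-yn-1-yl in place of hydrogen on an oxygen on an aromatic ring. The step bearing on this change is a 2.8-fold higher number from compound 1 to compound 2 (0.45 log units; beyond the scatter): reading it in reverse, putting a carbon chain back onto that oxygen should lower the number again by a modest amount. Compound 3 carries a similar alkynyl chain on the same oxygen and gives 4.1 nM, a number within the scatter of compound 2, so the gain is not expected to be large. Compound 4 is therefore estimated at 2.8 nM, expected to fall between 1.2 nM and 6.5 nM, which means an expected step of a 2.0-fold lower number from compound 2 to compound 4 (0.31 log units; beyond the scatter).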

Compound 4, half-maximal inhibitory concentration: 21.1 nM
For compound 4 the middle estimate is 7.5-fold (0.88 log units) below the measured one; the whole stated range lies below it.
By their numbers in this assay, from the lowest: compound 1; then compounds 3 and 2 (each within the scatter of the next); then compound 4.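

In this assay, among these compounds, a carbon chain on this oxygen does not always lower the number: the earlier compounds showed this only for methyl, whereas pent-2-yn-1-yl in place of hydrogen gives a 3.7-fold higher number from compound 2 to compound 4 (0.57 log units; beyond the scatter), so the direction of the change depends on the group that enters. Read from the methyl ether, but-1-yn-1-yl in place of hydrogen on the saturated chain carbon bound to that oxygen gives a 10-fold higher number from compound 1 to compound 4 (1.02 log units; beyond the scatter), a large loss from extending the group at this one place. No measurement available here accounts for this reversal.

Open, as far as these compounds go, is where between methyl and pent-2-yn-1-yl the change reverses, which an ethyl or propyl group on this oxygen could help to place. From the compounds shown here alone, it also remains open whether the triple bond matters or only the chain, a question that a saturated pentyl chain would address.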